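Removing the chloro from an antiproliferative hydrazone

A few compounds are considered here, and "the series" means these few. Any claim that something is new, unique, unknown or untested is made for them only; others in the source may bear on it.

Of the compounds shown here, two have been tested in a functional assay on SW-620 cells (Homo sapiens) for antiproliferative activity, read by sulforhodamine B assay, with a stated time of 48 h; on this read-out lower numbers stand for stronger inhibition of growth and higher numbers for weaker inhibition of growth. Compound 1 `COc1ccc(OC)c(/C=C/c2nnc(Nc3ccc(Cl)cc3)o2)c1` gives 18300 nM, whereas compound 2 `COc1ccc(OC)c(/C=C/C(=O)N/N=C/c2ccc(Cl)cc2)c1` gives 81.3 nM, the lower of the two numbers and a gap that lies well beyond the scatter. Compound 3 `COc1ccc(OC)c(/C=C/C(=O)N/N=C/c2ccccc2)c1` is not yet measured. It differs from compound 2 by hydrogen in place of chloro on an aromatic carbon. For the measured compounds named here, no measured pair shows this change here, so the step from compound 2 to compound 3 is expected to be a modest weakening, a 2.5-fold higher number from compound 2 to compound 3 (0.39 log units; beyond the scatter). Compound 3 is therefore estimated at 200 nM, within 60 nM to 700 nM.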

Compound 3, concentration for 50% growth inhibition: 1500 nM
Estimate against measurement, compound 3: 7.5-fold (0.88 log units) below, outside the stated range (above it).
By their numbers in this assay, from the lowest: compound 2; then compound 3; then compound 1.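

The step of an 18-fold higher number from compound 2 to compound 3 (1.27 log units; beyond the scatter) in this assay shows that the single chlorine, on an aromatic carbon para to a large group, accounts for much of the growth inhibition seen with the 4-chlorophenyl group. Compound 1 differs from compound 2 in more than one place, so the earlier pair could not isolate this contribution. Nothing available explains why this change has so large an effect. From the compounds shown here alone, whether a fluoro, a methyl or an amine at this position would match chloro or hydrogen remains open.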